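Shortening the acid side chain on the shared core

The compounds below may be only part of what the source reports. "The series", "measured", "known", "first", "only" and "open" are said of these compounds alone.

Compound 1, `CCC(C(=O)O)c1nn(Cc2cn3cc(OCC4CC4)c(Cl)cc3n2)c2ccccc2c1=O`: 5.6 nM
Compound 2, `COc1cc(OC)c(NC(=O)Cc2nn(CC(=O)O)c(=O)c3ccccc23)cc1Cl`: 186 nM
Compound 3, `O=C(O)C1(c2nn(Cc3cn4cc(OCC5CC5)c(Cl)cc4n3)c3ccccc3c2=O)CC1`: 16 nM

Of the compounds shown here, three have been measured in a functional assay on CHO cells for antagonist activity at sphingosine 1-phosphate receptor 2 (Homo sapiens), read by calcium flux; on this read-out lower numbers stand for stronger inhibition and higher numbers for weaker inhibition. Going by the values given here, compound 3 stands second highest of the three numbers: compound 1 gives the lowest number, and the gap is a 2.9-fold higher number from compound 1 to compound 3 (0.46 log units; beyond the scatter), while compound 2 gives by far the highest number, well above compound 3, although no single-change step connects compound 2 to the other two.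

Compound 4, `C[C@H](C(=O)O)c1nn(Cc2cn3cc(OCC4CC4)c(Cl)cc3n2)c2ccccc2c1=O`, has not yet been measured. It differs from compound 3 in one place: 1-carboxyethyl in place of 1-carboxycyclopropyl on an aromatic carbon. Among the compounds with values here, the only measured step that bears on this change is the one between compound 1 and compound 3, a 2.9-fold higher number from compound 1 to compound 3 (0.46 log units; beyond the scatter), where an open-chain 1-carboxypropyl gave a clearly lower number than 1-carboxycyclopropyl. Compound 4 again carries an open chain, 1-carboxyethyl with one defined stereocentre, so a step back toward lower numbers of roughly that size is expected, a 2.3-fold lower number from compound 3 to compound 4 (0.36 log units; beyond the scatter). Compound 4 is therefore expected to give about 7 nM in this assay, with a range from 2.5 nM to 20 nM.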

Compound 4, half-maximal inhibitory concentration: 3.2 nM
Compound 4: the middle estimate sits 2.2-fold (0.34 log units) above what was measured, within the range that was stated.
By their numbers in this assay, from the lowest: compounds 4 and 1 (each within the scatter of the next); then compound 3; then compound 2.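

In this assay, going from the ring to an open chain at this position again gives a lower number, here a 5.0-fold lower number from compound 3 to compound 4 (0.70 log units; beyond the scatter), so compound 3 now stands above two open-chain compounds rather than one. The two open chains themselves cannot be told apart, with a 1.8-fold lower number from compound 1 to compound 4 (0.24 log units; within the scatter), so 1-carboxyethyl and 1-carboxypropyl serve equally well on this read-out. Among these three compounds, the clear divide at this position lies between the three-membered carbon ring and an open chain, not between the two chain lengths.

Nothing available explains why the ring gives the higher number. Also open, on these data alone, is whether the opposite stereocentre of the 1-carboxyethyl group, a longer chain such as 1-carboxybutyl, or an amide in place of the carboxylic acid would keep these low numbers on the shared core.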